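The compounds below may be only part of what the source reports. "The series", "measured", "known", "first", "only" and "open" are said of these compounds alone.

Among the compounds with values here, compound 1 `COc1ccccc1-n1c(-c2coc3cc(C)c(Cl)cc3c2=O)nc(-c2ccccc2)c1-c1ccccc1` is one of two compounds measured so far in a functional assay on A549 cells (Homo sapiens) for inhibition, read by MTT assay, with a stated time of 72 h; a lower number here means a stronger inhibitor, a higher number a weaker inhibitor; compound 1 gives 12500 nM, and compound 2 `Cc1cc2occ(-c3nc(-c4ccccc4)c(-c4ccccc4)n3-c3cccc(Cl)c3)c(=O)c2cc1Cl` gives 25000 nM, the two lying within the scatter of each other. Within the data shown here, the single step between them, a 2.0-fold higher number from compound 1 to compound 2 (0.30 log units; within the scatter), likewise exchanges the 2-methoxyphenyl on the aromatic nitrogen and stays within the scatter. Compound 3 `Cc1cc2occ(-c3nc(-c4ccccc4)c(-c4ccccc4)n3-c3cccc([N+](=O)[O-])c3)c(=O)c2cc1Cl` is not yet measured and differs from compound 1 by 3-nitrophenyl in place of 2-methoxyphenyl on an aromatic nitrogen. On that one step, compound 3 is expected to give a 1.6-fold higher number from compound 1 to compound 3 (0.20 log units; within the scatter), nothing beyond the scatter. The estimate for compound 3 in this assay is 20000 nM, range 8000 nM to 50000 nM.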

Compound 3, half-maximal inhibitory concentration: 6250 nM
Compound 3: middle estimate off by 3.2-fold (0.51 log units), on the high side; the whole stated range lies above it.
By their numbers in this assay, from the lowest: compounds 3, 1 and 2 (each within the scatter of the next, the first and the last beyond it).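

On the aromatic nitrogen of the shared core, a change of the phenyl substituent now moves the number beyond the scatter in this assay: nitro in place of chloro gives a 4.0-fold lower number from compound 2 to compound 3 (0.60 log units; beyond the scatter), a modest step. The exchange of 2-methoxyphenyl for 3-nitrophenyl, a 2.0-fold lower number from compound 1 to compound 3 (0.30 log units; within the scatter), stays within the scatter, so compound 1 and compound 3 remain unseparated. No measurement bears on why nitro and chloro differ here.

The compounds shown leave open whether an amine or a carboxylic acid in place of the nitro would hold this level. They also leave open how 3-methoxyphenyl would compare, which would separate the group from its place on the ring.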